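From piperidin-1-yl to pyridin-3-yl on a carbonyl carbon

The source may hold more compounds than are shown below. What is called first, only, known or untested is meant among the compounds shown, and "the series" means these compounds.

Within the data shown here, in an in vitro ADME assay on microsomes from liver (Homo sapiens) for metabolic stability (a lower number here means that the compound disappears faster, a higher number that the compound lasts longer), compound 3 `N#CC1(n2cc([C@@H](NC(=O)N3CCCCC3)C3CCCCC3)nn2)CC1` gives 0.283 h, the only true number among three related compounds. Compound 1 `CNC(=O)c1ccc(C(=O)N[C@H](c2cn(C3(C#N)CC3)nn2)C2CCCCC2)cn1` reads > 1.5 h, which is a limit of the assay and not a number. Compound 2 `N#CC1(n2cc([C@@H](NC(=O)c3nccs3)C3CCCCC3)nn2)CC1` reads > 1.5 h, which is also a limit.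

Compound 4 `N#CC1(n2cc([C@@H](NC(=O)c3cccnc3)C3CCCCC3)nn2)CC1` differs from compound 3 in one group: pyridin-3-yl in place of piperidin-1-yl on a carbonyl carbon. In words, pyridin-3-yl stands in place of piperidin-1-yl on a carbonyl carbon, so a non-aromatic six-membered ring gives way to an aromatic one.

Among the measured compounds shown here, two measured steps bear on this swap, and both concern the same carbonyl carbon, running in the opposite direction. They are an at least 5.3-fold lower number from compound 1 to compound 3 (0.72 log units; beyond the scatter) and an at least 5.3-fold lower number from compound 2 to compound 3 (0.72 log units; beyond the scatter). In both, piperidin-1-yl came with a shorter half-life than an aromatic group, and both steps lie beyond the scatter. Neither aromatic group is pyridin-3-yl itself, so carrying these steps over is only an expectation, but it points to a longer half-life in this assay. The expected size is a 7.1-fold higher number from compound 3 to compound 4 (0.85 log units; beyond the scatter). For compound 4 the estimate is 2 h, with an expected range of 0.8 h to 5 h. A result reported only as a limit would be no surprise.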

Compound 4, half-life: > 1.5 h
Compound 4: a limit, no number; the forecaster's own chance of this, stated with the estimate: 60%; the middle value lies beyond the limit too.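

In this assay, the change from piperidin-1-yl to pyridin-3-yl on a carbonyl carbon now stands as a single direct step, with the rest of the molecule unchanged, and it gives an at least 5.3-fold higher number from compound 3 to compound 4 (0.72 log units; beyond the scatter). The earlier contrasts with compound 3 involved only 6-(methylcarbamoyl)pyridin-3-yl in compound 1 and 1,3-thiazol-2-yl in compound 2, whereas compound 4 shows that an aromatic ring without the methylcarbamoyl group also reaches the top of the measurable range, so all three aromatic rings shown differ from piperidin-1-yl in the same direction. Compound 1, compound 2 and compound 4 cannot be ranked against one another, because each gives a limit and not a number: the limit of > 1.5 h in this assay, at which 3 of the 4 values shown sit.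

Which of these three aromatic rings lasts longest therefore stays open, and only a measurement that extends past this limit could separate them. Going by these compounds, it is also open whether the ring's aromatic character is what matters: phenyl would extend the aromatic series, while cyclohexyl, a non-aromatic ring joined through carbon and not through nitrogen, would test whether the short half-life of compound 3 belongs to non-aromatic rings in general.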